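Hexyloxy for propylsulfanyl on a shared core

The source may hold more compounds than are shown below. What is called first, only, known or untested is meant among the compounds shown, and "the series" means these compounds.

Three compounds share one core and are compared in an ADME assay on Akata cells (Homo sapiens) for cytotoxicity, with a stated time of 7 days; a higher number here means that more compound is tolerated, a lower number that less compound is tolerated. Compound 1 `Nc1nc(OCC(F)(F)F)c2ncn(/C=C3/CC3(CO)CO)c2n1` gives a limit rather than a number, > 20000 nM. Compound 2 `Nc1nc(OCc2ccccc2)c2ncn(/C=C3/CC3(CO)CO)c2n1` likewise gives only a limit, > 20000 nM. Compound 3 `CCCSc1nc(N)nc2c1ncn2/C=C1/CC1(CO)CO` also stands at a limit and not at a number, > 20000 nM. Among the measured compounds shown here, because all three sit at the limit of > 20000 nM in this assay, at which 3 of the 3 values shown sit, none of the measured steps can be read: the step that the two limits leave unreadable from compound 1 to compound 2, the step that the two limits leave unreadable from compound 1 to compound 3 and the step that the two limits leave unreadable from compound 2 to compound 3 are each of unreadable size. Compound 3 thus stands at the limit, with no number of its own among the three.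

Compound 4 `CCCCCCOc1nc(N)nc2c1ncn2/C=C1/CC1(CO)CO` differs from compound 3 in one place: hexyloxy in place of propylsulfanyl on an aromatic carbon. The measured steps bear on this change only in that every replacement at this aromatic carbon so far, whether a phenyl for trifluoromethyl, a propylsulfanyl for 2,2,2-trifluoroethoxy or a propylsulfanyl for benzyloxy, left the value at the limit, so neither a direction nor a size can be read from them. The step of a number no higher from compound 3 to compound 4 (the limit leaves the size open) is therefore estimated as none beyond the scatter. Compound 4 is expected to give 20000 nM, within 8000 nM to 60000 nM, most likely again as a limit rather than a number.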

Compound 4, half-maximal cytotoxic concentration: > 20000 nM
Compound 4: a limit, no number; the forecaster's own chance of this, stated with the estimate: 75%; the middle value lies on the limit itself.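

No new step can be read: the steps to compound 4 from compound 1, compound 2 and compound 3 each join two limits, because all four compounds sit at the same one: the limit of > 20000 nM in this assay, at which 4 of the 4 values shown sit.

The compounds shown leave open at what concentration any of the four would reach a half-maximal cytotoxic effect, and whether hexyloxy, propylsulfanyl, benzyloxy and 2,2,2-trifluoroethoxy differ at all in this assay.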